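A few compounds are considered here, and "the series" means these few. Any claim that something is new, unique, unknown or untested is made for them only; others in the source may bear on it.

In an ADME assay on MT2 cells (Homo sapiens) for cytotoxicity (a lower number here means that less compound is tolerated, a higher number that more compound is tolerated), the three measured compounds stand as follows:

Compound 1 `CC(C)=CCOc1cc(Nc2ncnc(Cl)n2)ccc1Cl` gives 45000 nM.
Compound 2 `COc1ncnc(Nc2ccc(Cl)c(OCC=C(C)C)c2)n1` gives 18000 nM.
Compound 3 `CC(C)=CCOc1cc(Nc2ncnc(Cl)n2)ccc1C#N` gives only a limit of the assay, > 100000 nM.

Compound 3 is thus known only by a limit, not by a number: it sits at the limit of > 100000 nM in this assay, at which 1 of the 3 values shown sits. Compared with compound 1, it shows an at least 2.2-fold higher number from compound 1 to compound 3 (0.34 log units; beyond the scatter), so it is the one whose number is known to be at least modestly higher, while its exact place remains open.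

Compound 4 `COc1ncnc(Nc2ccc(C#N)c(OCC=C(C)C)c2)n1` is the next compound to be measured. It differs from compound 3 in one place: methoxy in place of chloro on an aromatic carbon.

The same exchange has been measured once, between compound 1 and compound 2, where it gave a 2.5-fold lower number from compound 1 to compound 2 (0.40 log units; beyond the scatter). That single step is the only one that bears directly on the change ahead, and it points to a modestly lower number. Since compound 3 itself is only a limit, the starting point carries extra uncertainty.

For compound 4 the expected result is therefore 60000 nM, within a range from 25000 nM to 150000 nM. This estimate implies an expected step of an at least 1.6-fold lower number from compound 3 to compound 4 (0.22 log units; that floor lies within the scatter), modest and toward a lower number.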

Compound 4, half-maximal cytotoxic concentration: 42000 nM
Compound 4: middle estimate off by 1.4-fold (0.15 log units), on the high side; the measured number falls inside the stated range.
By their numbers in this assay, from the lowest: compound 2; then compounds 4 and 1 (each within the scatter of the next). At a limit, above all of these: compound 3.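

In this assay, methoxy in place of chloro on the aromatic carbon between two ring nitrogen atoms gives an at least 2.3-fold lower number from compound 3 to compound 4 (0.37 log units; beyond the scatter), so the lowering seen earlier with chloro on the core of compound 1 also appears on a second core, the one carrying cyano: the same change on two cores in this assay, a 2.5-fold lower number (0.40 log units; beyond the scatter) from compound 1 to compound 2 and an at least 2.3-fold lower number (0.37 log units; beyond the scatter) from compound 3 to compound 4; the limit leaves it open whether they differ

The cyano exchange can now be read against a measured number at both ends, as it gives a 2.3-fold higher number from compound 2 to compound 4 (0.37 log units; beyond the scatter), and so it too holds on two cores: the same change on two cores in this assay, an at least 2.2-fold higher number (0.34 log units; beyond the scatter) from compound 1 to compound 3 and a 2.3-fold higher number (0.37 log units; beyond the scatter) from compound 2 to compound 4; the limit leaves it open whether they differ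

Compound 3 remains a limit, so the full size of its step stays unknown: the limit of > 100000 nM in this assay, at which 1 of the 4 values shown sits.

The compounds shown leave open whether either exchange differs in size from one core to the other. They also leave open how an amine or an ethoxy group at this position would compare with methoxy and chloro.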